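Chain Shortening Compared Across Two Related Cores

This account rests on a few compounds, and the source may have more. Where it says the series, first, only, none or still open, it means among the compounds named here.

Compound 1 `CCCCCCCCCCCCCCNNC(=O)COC` and compound 2 `CCCCCCCCCCNNC(=O)COC` share one core, while compound 3 `CCCCCCCCCCCC/C=C/N(NC(=O)COC)C(=O)OC(C)(C)C` is built on a second core; the difference between the two cores is not broken down here. In a functional assay on HeLa cells (Homo sapiens) for cytotoxicity, with a stated time of 72 h (a lower number here means that less compound is tolerated, a higher number that more compound is tolerated), compound 1 gives 59600 nM, compound 2 gives 138000 nM and compound 3 gives 57700 nM. The change hydrogen in place of butyl on a saturated chain carbon, ten or more bonds along the chain from an amine nitrogen produced a 2.3-fold higher number from compound 1 to compound 2 (0.36 log units; beyond the scatter). Compound 4 `CCCCCCCC/C=C/N(NC(=O)COC)C(=O)OC(C)(C)C` arises from compound 3 by the same kind of change, (hydrogen in place of butyl on a saturated chain carbon, eight bonds along the chain from a double-bonded chain carbon). Because the earlier step was a 2.3-fold higher number from compound 1 to compound 2 (0.36 log units; beyond the scatter), compound 4 is expected to show a 2.3-fold higher number from compound 3 to compound 4 (0.35 log units; beyond the scatter) in this assay. Compound 4 is therefore estimated at 130000 nM, with a likely range from 65000 nM to 260000 nM.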

Compound 4, half-maximal cytotoxic concentration: 83200 nM
Compound 4: the middle estimate sits 1.6-fold (0.19 log units) above what was measured, within the range that was stated.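

In this assay, hydrogen in place of butyl gives a 1.4-fold higher number from compound 3 to compound 4 (0.16 log units; within the scatter) on the second core, so on this core the step alone cannot be told apart from repeat scatter. Set beside the earlier step, it does not differ by more than two such steps can: the same change on two cores in this assay, a 2.3-fold higher number (0.36 log units; beyond the scatter) from compound 1 to compound 2 and a 1.4-fold higher number (0.16 log units; within the scatter) from compound 3 to compound 4, 1.6-fold (0.21 log units) apart, within the scatter of two such steps

The change therefore carries over between these two cores as far as this comparison can show, but that rests on a single step on each core and does not show that the size of the step holds for other chain lengths or other cores.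

The compounds shown leave open how a longer chain, or a chain ending in an amine or a carboxylic acid, would behave on either core. The difference between the two cores also remains to be taken apart.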